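Iminosugar acid stereoisomers against alpha-N-acetylgalactosaminidase

This account rests on a few compounds, and the source may have more. Where it says the series, first, only, none or still open, it means among the compounds named here.

Compound 3 `O=C(O)[C@H]1NC[C@H](O)[C@@H](O)[C@H]1O` gives 31% in an assay for inhibition of alpha-N-acetylgalactosaminidase (Gallus gallus), tested at 1000 uM (on this read-out higher numbers stand for more inhibition at the one concentration tested (going by the name of the read-out) and lower numbers for less inhibition), and is the highest of the three numbers measured. Compound 1 `O=C(O)[C@H]1NC[C@@H](O)[C@H](O)[C@H]1O` gives 4.2%, and compound 2 `O=C(O)[C@@H]1NCC=C[C@@H]1O` gives 1.3%. Within the data shown here, the only step between measured compounds is a number 26.8 percentage points higher from compound 1 to compound 3 (beyond the scatter); this rise is attributed to the fact that compounds 1 and 3 differ only in the configuration as drawn, showing that the configuration at ring carbons alone can move the read-out by a modest amount.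

Compound 4 `O=C(O)[C@@H]1NC[C@@H](O)[C@H](O)[C@H]1O` is the next stereoisomer to be tested. the two compounds have the same atoms and bonds and differ only in configuration as drawn: 3 of 4 stereo elements differ; a stereocentre at a saturated ring carbon is drawn S in compound 3 and R in compound 4; a stereocentre at a saturated ring carbon is drawn S in compound 3 and R in compound 4; a stereocentre at a saturated ring carbon is drawn R in compound 3 and S in compound 4

The step from compound 1 to compound 3 is the one that bears here: two inverted centres gave a modest gain. Compound 4 inverts three of the four centres of compound 3, so the arrangement that carries the gain of compound 3 is not kept, and a step back toward the level of compound 1 and compound 2 is expected in this assay, of a size beyond the scatter. The estimate for compound 4 is 8%, between 1% and 25%, an expected change of a number 23 percentage points lower from compound 3 to compound 4 (beyond the scatter).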

Compound 4, a percentage reported as inhibition, at one concentration (the size of the read-out at that concentration, not a potency): 1.3%
Compound 4: middle estimate off by 6.7 percentage points, on the high side; the measured number falls inside the stated range.
By their numbers in this assay, from the lowest: compounds 2, 4 and 1 (each within the scatter of the next); then compound 3.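

In this assay, three inverted centres give a number 29.7 percentage points lower from compound 3 to compound 4 (beyond the scatter), so the level of compound 3 does not survive this wider change of configuration. One inverted centre gives a number 2.9 percentage points lower from compound 1 to compound 4 (within the scatter), which means that this single inversion, a stereocentre at a saturated ring carbon drawn S in one compound and R in the other, has no readable effect when it starts from the low level. Compound 3 thus stands alone among the three stereoisomers, and the separation from it follows configuration alone: the fact that compounds 3 and 4 differ only in the configuration as drawn

As far as these compounds go, each step from compound 3 changes two or three centres together, and which of those centres carries its number remains open. Also open, from the compounds shown here alone, is how an acetamido group in place of one hydroxyl on the shared core would read in this assay.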